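The source may report more compounds than this note shows. Statements on the series, on what has been measured and on what is new or still open speak of the compounds shown alone.

Compound 1, `COc1cc(/C=N/Nc2nc(-c3ccc(Br)cc3)cs2)cc(Br)c1OC`: in a functional assay on U-87MG ATCC cells for inhibition, with U-87 MG (Homo sapiens) as the target, read by MTT assay, with a stated time of 48 h (a lower number here means a stronger inhibitor, a higher number a weaker inhibitor), compound 1 gives 27900 nM.
Compound 2, `COc1ccccc1-c1csc(N/N=C/c2cc(OC)c(OC)c(Br)c2Br)n1`: in this assay compound 2 gives only a limit, > 100000 nM, not a number.
Compound 3, `COc1cc(/C=N/Nc2nc(-c3cccc(Br)c3)cs2)c(Br)c(Br)c1OC`: in this assay compound 3 gives 27600 nM.

Compound 3 holds the lowest of the two numbers, with compound 1 within the scatter of it; the remaining value is a limit, (the limit of > 100000 nM in this assay, at which 1 of the 3 values shown sits). Compound 4, `COc1cc(/C=N/Nc2nc(-c3ccc(Br)cc3)cs2)c(Br)c(Br)c1OC`, differs from compound 3 by 4-bromophenyl in place of 3-bromophenyl on an aromatic carbon. Among the compounds with values here, only one measured step touches this part of the molecule, an at least 3.6-fold lower number from compound 2 to compound 3 (0.55 log units; beyond the scatter), which exchanged a different group for the one that now leaves, so it gives little direct guidance. Compound 1 already carries the 4-bromophenyl group that enters here, and its value and that of compound 3 sit within the scatter of each other. The step of a 1.0-fold higher number from compound 3 to compound 4 (0.01 log units; within the scatter) is therefore expected to be small, with no clear direction beyond the scatter. Compound 4 is expected to give 28000 nM, in a range from 12000 nM to 70000 nM.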

Compound 4, half-maximal inhibitory concentration: > 100000 nM
Compound 4: no number, only a limit; the forecaster's own chance of this, stated with the estimate: 10%; middle value at least 3.5-fold (0.55 log units) from the limit.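

In this assay compound 4 gives only a limit, not a number, and it shares that limit with compound 2: the limit of > 100000 nM in this assay, at which 2 of the 4 values shown sit. Although the two groups hold the same atoms, 4-bromophenyl in place of 3-bromophenyl gives an at least 3.6-fold higher number from compound 3 to compound 4 (0.55 log units; beyond the scatter), so at this position on the shared core the place of the bromine on the phenyl ring matters. With 4-bromophenyl kept, bromo in place of hydrogen on the other aromatic ring gives an at least 3.5-fold higher number from compound 1 to compound 4 (0.55 log units; beyond the scatter), so this second change also separates two compounds by more than the scatter.

The step between compound 2 and compound 4 cannot be read, since both are limits. As far as these compounds go, it remains open whether an amine or a carboxylic acid on the phenyl ring, in place of the bromine of compound 4, would bring a measurable number back.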